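The compounds below may be only part of what the source reports. "The series", "measured", "known", "first", "only" and "open" are said of these compounds alone.

Of the compounds shown here, three have so far been measured in a functional assay on UACC-62 cells (Homo sapiens) for cytotoxicity, read by sulforhodamine B assay, with a stated time of 48 h, tested at 1 uM; a lower number here means a stronger effect, a higher number a weaker effect of the compound at the concentration tested. Compound 1 `COc1cc(C)cc(-c2c(-c3ccnc(-c4ccc(N(C)C)cc4)c3)cnn2CC#N)c1` gives 18%, the highest of the three numbers, though all three sit within the usual scatter of one another. Compound 2 `COc1cc(C)cc(-c2nn(CC#N)cc2-c2ccnc(-c3ccc(N(C)C)cc3)c2)c1` gives 12%, and compound 3 `Cc1cc(O)cc(-c2nn(CC#N)cc2-c2ccnc(-c3ccc(N(C)C)cc3)c2)c1` gives 10%. For the measured compounds named here, the single one-place step among them, a number 2 percentage points lower from compound 2 to compound 3 (within the scatter), concerns a hydrogen in place of methyl on an oxygen on an aromatic ring and stays within the scatter. Compound 4 `COc1cc(C)cc(-c2c(-c3ccnc(-c4ccc(C(C)=O)cc4)c3)cnn2CC#N)c1` differs from compound 1 in a different group: acetyl in place of dimethylamino on an aromatic carbon. Going by the values given here, no measured step exchanges dimethylamino for anything else, so the three measured compounds give no direct guide to the size or direction of this change; the one step that exists touches another group and is itself small. With no evidence pointing either way, compound 4 is expected to give about 20%, within a wide range from 5% to 45%. The step of a number 2 percentage points higher from compound 1 to compound 4 (within the scatter) is thus estimated to remain within the scatter.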

Compound 4, a percentage reported as activity, at one concentration (the size of the read-out at that concentration, not a potency): 25%
Beside the measured number, compound 4's estimate is 5 percentage points below it; low and high end bracket the measured number.
By their numbers in this assay, from the lowest: compounds 3, 2, 1 and 4 (each within the scatter of the next, the first and the last beyond it).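

In this assay, putting acetyl in place of dimethylamino on this aromatic carbon, para to a large group, gives a number 7 percentage points higher from compound 1 to compound 4 (within the scatter), so this one exchange at this place leaves the read-out within the usual scatter. The two groups have the same count of heavy atoms and of hydrogen-bond acceptors, yet they differ in one atom and in the double bond of acetyl, and the pair shows that dimethylamino is not needed to keep the read-out within that scatter at this single concentration. No measurement at hand explains this outcome.

On these data alone, what a carboxylic acid, a primary amine or a longer chain would do at this place remains open. Also open, as far as these compounds go, is whether acetyl would give a similar step on the core of compound 2.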